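Swapping the Ether Substituent: From Cyclopentyl to Benzyl

This account rests on a few compounds, and the source may have more. Where it says the series, first, only, none or still open, it means among the compounds named here.

Compound 1, `CCCOc1cc(C(C)(C)C)ccc1CNC(=O)C(C)c1ccc(NS(C)(=O)=O)c(F)c1`: 4.4 nM
Compound 2, `CC(C)CCOc1cc(C(C)(C)C)ccc1CNC(=O)C(C)c1ccc(NS(C)(=O)=O)c(F)c1`: 0.6 nM
Compound 3, `CC(C(=O)NCc1ccc(C(C)(C)C)cc1OC1CCCC1)c1ccc(NS(C)(=O)=O)c(F)c1`: 1.8 nM

These three compounds share one core and differ only in the group carried on the oxygen on the aromatic ring. In an assay on cells for antagonist activity at transient receptor potential cation channel subfamily V member 1 (Homo sapiens), read by FLIPR and calcium flux, with a stated time of 6 min (a lower number here means a stronger inhibitor, a higher number a weaker inhibitor), compound 3 gives 1.8 nM, which places it second highest among the three values, above compound 2 and below compound 1.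

The next compound, compound 4, is `CC(C(=O)NCc1ccc(C(C)(C)C)cc1OCc1ccccc1)c1ccc(NS(C)(=O)=O)c(F)c1`. Relative to compound 3 the change is benzyl in place of cyclopentyl on an oxygen on an aromatic ring.

Two measured steps speak to this position. Replacing propyl with cyclopentyl gave a 2.4-fold lower number from compound 1 to compound 3 (0.39 log units; beyond the scatter), and replacing cyclopentyl with isopentyl gave a 3.0-fold higher number from compound 2 to compound 3 (0.48 log units; beyond the scatter) read in reverse, so the open-chain isopentyl sat lowest. Among the measured compounds shown here, both steps were modest, and the group with more heavy atoms has so far gone with the lower number; no compound here runs against that. For the measured compounds named here, a benzyl is larger still, but it is aromatic rather than saturated, which no measured pair covers.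

For compound 4 a small downward step is expected, a 1.5-fold lower number from compound 3 to compound 4 (0.18 log units; within the scatter), giving an estimated value of 1.2 nM with a likely range from 0.4 nM to 4 nM.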

Compound 4, inhibition constant: 2.9 nM
Estimate against measurement, compound 4: 2.4-fold (0.38 log units) below; the range from low to high includes it.
By their numbers in this assay, from the lowest: compound 2; then compounds 3, 4 and 1 (each within the scatter of the next, the first and the last beyond it).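

Benzyl carries more heavy atoms than cyclopentyl, yet the change gives a 1.6-fold higher number from compound 3 to compound 4 (0.21 log units; within the scatter) in this assay, so the larger group brings no measurable gain here, and compound 4 goes against the earlier link between more heavy atoms and a lower number. Among the compounds shown here, compound 4 also cannot be told apart from the open-chain propyl ether, with a 1.5-fold lower number from compound 1 to compound 4 (0.18 log units; within the scatter), while the one step beyond the scatter, a 4.8-fold higher number from compound 2 to compound 4 (0.68 log units; beyond the scatter), shows that this aromatic group does not match the isopentyl of compound 2, which keeps the lowest number of the four. Nothing measured here explains why the aromatic ring departs from that link.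

The comparison mixes two changes, size and aromatic character, and a cyclohexylmethyl group, the saturated counterpart of benzyl, would be needed to separate them. From the compounds shown here alone, it also remains open whether the ring could do better farther from the oxygen, as in a phenethyl group, or with a nitrogen in the ring, as in a pyridylmethyl group.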